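Fluoro Substitution on the N-Aryl Ring of a Quinolone Amide

This account rests on a few compounds, and the source may have more. Where it says the series, first, only, none or still open, it means among the compounds named here.

Compound 1 `Cn1ccc2c(Oc3ccc(NC(=O)c4cn(-c5ccc(Br)cc5)c5ccccc5c4=O)cc3F)ccnc21` gives 1830 nM in a functional assay on MCF7 cells (Homo sapiens) for inhibition, read by MTT assay, with a stated time of 72 h; on this read-out lower numbers stand for stronger inhibition and higher numbers for weaker inhibition. Compound 2 `Cn1ccc2c(Oc3ccc(NC(=O)c4cn(-c5ccc(Br)cc5F)c5ccccc5c4=O)cc3F)ccnc21` carries fluoro in place of hydrogen on an aromatic carbon and gives 420 nM in this assay; the step is a 4.4-fold lower number from compound 1 to compound 2 (0.64 log units; beyond the scatter). Compound 3 `O=C(Nc1ccc(Oc2ccnc3[nH]ccc23)c(F)c1)c1cn(-c2ccccc2)c2ccccc2c1=O` rests on a different core, and the difference between the two cores is not broken down here. In this assay compound 3 gives 430 nM, a value within the scatter of that of compound 2. Compound 4 `O=C(Nc1ccc(Oc2ccnc3[nH]ccc23)c(F)c1)c1cn(-c2ccc(F)cc2)c2ccccc2c1=O` has not been measured yet; it differs from compound 3 by fluoro in place of hydrogen on an aromatic carbon. This is the same kind of change as that from compound 1 to compound 2, but not the same: in compound 2 the fluoro sits ortho to a large group and meta to a bromo group, whereas in compound 4 it sits para to a large group. Because the earlier step was a 4.4-fold lower number from compound 1 to compound 2 (0.64 log units; beyond the scatter), a smaller change is expected from compound 3 to compound 4, a 1.4-fold lower number from compound 3 to compound 4 (0.16 log units; within the scatter). Compound 4 is therefore estimated at 300 nM, with a range from 120 nM to 900 nM.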

Compound 4, half-maximal inhibitory concentration: 520 nM
Compound 4: middle estimate off by 1.7-fold (0.24 log units), on the low side, and the stated range covers the measured number.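

In this assay, fluoro in place of hydrogen on the core of compound 3 gives a 1.2-fold higher number from compound 3 to compound 4 (0.08 log units; within the scatter). Set beside the earlier step, the change does not carry over from one core to the other with the same size: the same change on two cores in this assay, a 4.4-fold lower number (0.64 log units; beyond the scatter) from compound 1 to compound 2 and a 1.2-fold higher number (0.08 log units; within the scatter) from compound 3 to compound 4, 5.3-fold (0.72 log units) apart, beyond the scatter of two such steps This does not show that the core alone separates the two steps, for the fluoro in compound 4 stands para to a large group, while that in compound 2 stands elsewhere, on a ring that also bears a bromo group, so core and place change together.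

The compounds shown leave open what the same placement of fluoro would give on both cores. They also leave open whether a chloro or a methoxy group would follow the fluoro on the core of compound 3.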